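The compounds below may be only part of what the source reports. "The series", "measured", "known", "first", "only" and "open" are said of these compounds alone.

The series shares one core. Compound 1 `NC[C@@H]1CCCc2cc(S(=O)(=O)c3cccc(F)c3)ccc21` carries a free amine; compound 2 `O=S(=O)(c1cccc(F)c1)c1ccc2c(c1)CCC[C@H]2CNCCO` and compound 3 `CNCC(=O)NC[C@@H]1CCCc2cc(S(=O)(=O)c3cccc(F)c3)ccc21` carry substituents on that nitrogen. In an assay on isolated protein for displacement of a labelled ligand from 5-hydroxytryptamine receptor 6 (Homo sapiens) (a higher number here means a weaker inhibitor, a lower number a stronger inhibitor), compound 1 gives 0.0794 nM, compound 2 gives 0.126 nM, and compound 3 gives 0.159 nM, the highest of the three numbers, though a 2.0-fold higher number from compound 1 to compound 3 (0.30 log units; within the scatter) and a 1.3-fold higher number from compound 2 to compound 3 (0.10 log units; within the scatter) both stay within the scatter, as does a 1.6-fold higher number from compound 1 to compound 2 (0.20 log units; within the scatter). Compound 4 `NC(=O)NC[C@@H]1CCCc2cc(S(=O)(=O)c3cccc(F)c3)ccc21` differs from compound 3 by amino in place of (methylamino)methyl on a carbonyl carbon. For the measured compounds named here, the steps that bear on this are the substitutions at the amine nitrogen, which moved the number little; a change on the same carbonyl is therefore expected to leave compound 4 near the others, with no step beyond the scatter. For compound 4 the estimate in this assay is 0.13 nM, range 0.05 nM to 0.35 nM, an expected step of a 1.2-fold lower number from compound 3 to compound 4 (0.09 log units; within the scatter).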

Compound 4, inhibition constant: 0.2 nM
Beside the measured number, compound 4's estimate is 1.5-fold (0.19 log units) below it, within the range that was stated.
By their numbers in this assay, from the lowest: compounds 1, 2, 3 and 4 (each within the scatter of the next, the first and the last beyond it).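

On the carbonyl carbon, amino in place of (methylamino)methyl gives a 1.3-fold higher number from compound 3 to compound 4 (0.10 log units; within the scatter) and leaves the number within the scatter. Carbamoyl in place of 2-hydroxyethyl on the amine nitrogen gives a 1.6-fold higher number from compound 2 to compound 4 (0.20 log units; within the scatter) and also stays within it. Carbamoyl in place of hydrogen on that nitrogen gives a 2.5-fold higher number from compound 1 to compound 4 (0.40 log units; beyond the scatter) and is the only step in the series beyond the scatter, though a modest one.

Open, from the compounds shown here alone, is whether a longer chain or a carboxylic acid in place of amino on the carbonyl carbon would keep the number near these values. Nothing at hand accounts for the modest step.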